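The compounds below may be only part of what the source reports. "The series", "measured", "known", "first", "only" and "open" are said of these compounds alone.

Measured so far in this series:

compound 1 `CCCc1c(OC)nc2nc(-c3nnc(C)o3)cn2c1C` — 10 mg/kg
compound 2 `C=CCc1c(OC)nc2nc(-c3nnc(C)o3)cn2c1C` — 10 mg/kg
compound 3 `CCCc1c(OC)nc2nc(-c3nc(C)cs3)cn2c1C` — a limit only, > 50 mg/kg

In a functional assay on the whole organism with Rattus norvegicus as the target (on this read-out lower numbers stand for an effect already at smaller amounts and higher numbers for an effect only at larger amounts of compound), compound 1 gives 10 mg/kg and compound 2 gives 10 mg/kg. For compound 3 this assay reports no number but a limit, > 50 mg/kg (the limit of > 50 mg/kg in this assay, at which 1 of the 3 values shown sits). Between compound 1 and compound 3 the change is 4-methyl-1,3-thiazol-2-yl in place of 5-methyl-1,3,4-oxadiazol-2-yl on an aromatic carbon and the step is an at least 5.0-fold higher number from compound 1 to compound 3 (0.69 log units; beyond the scatter). Between compound 1 and compound 2 the change is vinyl in place of ethyl on a saturated chain carbon bound to an aromatic carbon and the step is no change at the digits printed from compound 1 to compound 2 (within the scatter).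

Compound 4 `C=CCc1c(OC)nc2nc(-c3nc(C)cs3)cn2c1C` has not been measured in this assay. It differs from compound 3 by vinyl in place of ethyl on a saturated chain carbon bound to an aromatic carbon, the same change as from compound 1 to compound 2, made on the same place word for word; the two cores differ as told under (4-methyl-1,3-thiazol-2-yl in place of 5-methyl-1,3,4-oxadiazol-2-yl on an aromatic carbon). In this assay a step that the limit leaves unreadable from compound 3 to compound 4 is expected, resting on no change at the digits printed from compound 1 to compound 2 (within the scatter), where the same change left the read-out unchanged. Since compound 3 sits at a limit, compound 4 is expected to sit at or near that limit as well. The estimate for compound 4 is 60 mg/kg, from 35 mg/kg to 150 mg/kg.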

Compound 4, minimum effective dose: > 50 mg/kg
Compound 4: no number, only a limit (the forecaster's own chance of this, stated with the estimate: 80%); the middle value is on the limit's open side.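

With allyl on the shared core, 4-methyl-1,3-thiazol-2-yl in place of 5-methyl-1,3,4-oxadiazol-2-yl gives an at least 5.0-fold higher number from compound 2 to compound 4 (0.69 log units; beyond the scatter) in this assay, so this exchange points the same way on the propyl and allyl cores, though whether its size is the same stays unsettled: the same change on two cores in this assay, an at least 5.0-fold higher number (0.69 log units; beyond the scatter) from compound 1 to compound 3 and an at least 5.0-fold higher number (0.69 log units; beyond the scatter) from compound 2 to compound 4; the limit leaves it open whether they differ

Compound 3 and compound 4 each sit at a limit, so the step from compound 3 to compound 4 cannot be read. The absence of a readable change from compound 1 to compound 2 therefore cannot be shown to carry over to the core of compound 3: the limit of > 50 mg/kg in this assay, at which 2 of the 4 values shown sit.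

Still open, as far as these compounds go, is how a longer chain such as butyl, or a chain ending in an amine, would read out in place of propyl on the core of compound 1. Also open, from the compounds shown here alone, is whether a methyl ester in place of 5-methyl-1,3,4-oxadiazol-2-yl would stay level with compound 1 or move towards the limit.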